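Nitro in place of dimethylamino in the series

A few compounds are considered here, and "the series" means these few. Any claim that something is new, unique, unknown or untested is made for them only; others in the source may bear on it.

In a functional assay on MCF7 cells (Homo sapiens) for cytotoxicity, read by sulforhodamine B assay (on this read-out lower numbers stand for stronger inhibition of growth and higher numbers for weaker inhibition of growth), compound 1 (`CC1=CC[C@@H]([C@@](C)(O)CCCC(C)(C)NC(=S)N/N=C\c2ccccc2)CC1`) gives 28700 nM. Compound 2 (`CC1=CC[C@@H]([C@@](C)(O)CCCC(C)(C)NC(=S)N/N=C\c2ccc(N(C)C)cc2)CC1`) gives > 100000 nM, which is only a limit of the assay, so no number places it.

The change to compound 3 (`CC1=CC[C@@H]([C@@](C)(O)CCCC(C)(C)NC(=S)N/N=C\c2ccc([N+](=O)[O-])cc2)CC1`) is nitro in place of dimethylamino on an aromatic carbon, para to a large group. Going by the values given here, one measured step bears on it: an at least 3.4-fold higher number from compound 1 to compound 2 (0.54 log units; beyond the scatter), the step that adds the dimethylamino now leaving. Among the compounds with values here, no measured step carries nitro, so this guide is partial.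

With that group gone, a step towards lower numbers is expected in this assay, back towards the level of compound 1, though the limit leaves its size open. The estimated step is an at least 2.8-fold lower number from compound 2 to compound 3 (0.45 log units; beyond the scatter). Compound 3 is expected at 35000 nM, with an estimated range of 12000 nM to 100000 nM.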

Compound 3, concentration for total growth inhibition: > 100000 nM
Compound 3: only a limit was reported; the forecaster's own chance of this, stated with the estimate: 25%; at least 2.8-fold (0.45 log units) between middle value and limit.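

In this assay, compound 3 gives > 100000 nM, which is a limit of the assay and not a number. Nitro in place of hydrogen on the aromatic carbon para to a large group gives an at least 3.4-fold higher number from compound 1 to compound 3 (0.54 log units; beyond the scatter), so nitro, like dimethylamino, moves the read-out towards weaker inhibition of growth, and the shift at this place is not confined to one group. The step between compound 2 and compound 3 cannot be read because both compounds stand at the same limit: the limit of > 100000 nM in this assay, at which 2 of the 3 values shown sit.

Where compound 2 and compound 3 truly lie stays open, so no order can be given between dimethylamino and nitro. Also open, from the compounds shown here alone, is whether a smaller group at this place, such as fluorine, methyl or hydroxyl, would stay near compound 1 at 28700 nM.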